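Triazolylmethyl spiro series: trichlorophenyl in place of dimethylphenyl

The source may hold more compounds than are shown below. What is called first, only, known or untested is meant among the compounds shown, and "the series" means these compounds.

Measured compounds in a functional assay on HCT-116 cells (Homo sapiens) for antiproliferative activity, read by MTT assay, with a stated time of 48 h; a higher number here means a weaker inhibitor, a lower number a stronger inhibitor:
Compound 1 `N#CC1=C(N)Oc2c(c3nc4ccccc4nc3c3ccccc23)C12C(=O)N(Cc1cnnn1-c1cccc(Cl)c1)c1ccccc12` gives > 50000 nM.
Compound 2 `N#CC1=C(N)Oc2c(c3nc4ccccc4nc3c3ccccc23)C12C(=O)N(Cc1cnnn1-c1ccc(Cl)c(Cl)c1)c1ccccc12` gives > 50000 nM.
Compound 3 `Cc1ccc(-n2nncc2CN2C(=O)C3(C(C#N)=C(N)Oc4c(N)cc5nc6ccccc6nc5c43)c3ccccc32)cc1C` gives > 50000 nM.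

Each of these three values is a limit of this assay, not a number. Compound 3 therefore stands only at a limit in this assay, and the two further values shown are limits as well, so no ordering among the three can be read. Among the measured compounds shown here, the one step between compounds differing in a single place, a step that the two limits leave unreadable from compound 1 to compound 2, is unreadable for the same reason, as the limit of > 50000 nM in this assay, at which 3 of the 3 values shown sit, shows.

Compound 4 `N#CC1=C(N)Oc2c(N)cc3nc4ccccc4nc3c2C12C(=O)N(Cc1cnnn1-c1c(Cl)cc(Cl)cc1Cl)c1ccccc12` differs from compound 3 by 2,4,6-trichlorophenyl in place of 3,4-dimethylphenyl on an aromatic nitrogen. For the measured compounds named here, no measured step bears directly on this change; what is known is that all three values sit at the limit. The expectation for the step that the limit leaves unreadable from compound 3 to compound 4 is therefore no readable movement, with compound 4 most likely also reported at the limit. Compound 4 is estimated at 60000 nM, within 20000 nM to 200000 nM, in this assay.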

Compound 4, half-maximal inhibitory concentration: 12100 nM
Compound 4: the middle estimate sits 5.0-fold (0.70 log units) above what was measured, outside the stated range (below it).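

In this assay, 2,4,6-trichlorophenyl in place of 3,4-dimethylphenyl on the aromatic nitrogen gives an at least 4.1-fold lower number from compound 3 to compound 4 (0.61 log units; beyond the scatter). Among the compounds shown here, this is the first readable movement, and it shows that the group on this nitrogen can change the read-out on the core of compound 3. Its size remains a minimum, and compound 4 is the only compound shown with a measured number: the limit of > 50000 nM in this assay, at which 3 of the 4 values shown sit.

Which part of the change carries the step remains open, as the two methyl groups leave and the three chlorines enter in one change, so neither the number of chlorines nor their placement can be separated. Also open, as far as these compounds go, is the response to other groups on this nitrogen, such as a phenyl ring bearing an amine or a carboxylic acid, and whether 2,4,6-trichlorophenyl has a similar effect on the core of compound 1.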